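Moving a nitrophenyl group on a short-lived compound

The compounds below may be only part of what the source reports. "The series", "measured", "known", "first", "only" and "open" are said of these compounds alone.

In an ADME assay on the whole organism with Canis familiaris (Canis lupus familiaris) as the target (on this read-out higher numbers stand for a longer-lived compound and lower numbers for a shorter-lived compound), compound 1 (`CCOC(=O)C1=C(C)N=C(C)N(C(=O)OCC)C1c1cccc([N+](=O)[O-])c1`) gives 0.00667 h and compound 2 (`CCCCCCCOC(=O)N1C(=O)NC(C)=C(C(=O)OCC2CC2)C1c1cccc([N+](=O)[O-])c1`) gives 0.0333 h as its result. Compound 2 therefore holds the higher of the two numbers, and the gap lies beyond the usual scatter of repeat measurements. These two compounds differ in more than one place, so their gap says nothing about any single change. Compound 3 (`CCCCCCCOC(=O)N1C(=O)NC(C)=C(C(=O)OCC2CC2)C1c1ccccc1[N+](=O)[O-]`) has the same atoms as compound 2, joined differently: 2-nitrophenyl in place of 3-nitrophenyl on a saturated ring carbon. For the measured compounds named here, no measured pair shows what such a swap does, so no step beyond the scatter is expected in either direction. The expected change is a 1.1-fold lower number from compound 2 to compound 3 (0.05 log units; within the scatter) and stays within that scatter. For compound 3 the estimated half-life is 0.03 h with a likely range from 0.01 h to 0.09 h on this scale.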

Compound 3, half-life: 0.0667 h
Beside the measured number, compound 3's estimate is 2.2-fold (0.35 log units) below it, and the stated range covers the measured number.
By their numbers in this assay, from the lowest: compound 1; then compounds 2 and 3 (each within the scatter of the next).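

In this assay, for the compounds shown here, this is the first comparison in which only one thing changes: 2-nitrophenyl in place of 3-nitrophenyl on a saturated ring carbon gives a 2.0-fold higher number from compound 2 to compound 3 (0.30 log units; within the scatter). With the heptyloxycarbonyl and cyclopropylmethoxycarbonyl groups held fixed, the two arrangements therefore cannot be told apart in half-life, and the place of the nitro group on this phenyl ring has no effect here that repeat measurements could separate from scatter. Nothing available explains this result or links it to any property of either group.

Going by these compounds, it remains open whether the same swap would give a similar result with other groups on the shared core, such as a shorter chain in place of heptyl. On these data alone, it is also open what an amine or a carboxylic acid in place of the nitro group would do at this position.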